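Swapping the aryl group on compound 2's pyridazinone nitrogen

This account rests on a few compounds, and the source may have more. Where it says the series, first, only, none or still open, it means among the compounds named here.

Of the compounds shown here, two with a shared amide core have been tested in a functional assay on MCF7 cells (Homo sapiens) for cytotoxicity, read by MTT assay, with a stated time of 72 h; a lower number here means a stronger inhibitor, a higher number a weaker inhibitor. Compound 1 `CNC(=O)c1cc(Oc2ccc(NC(=O)c3nn(-c4ccc(C)cc4)c(=O)cc3C)cc2F)ccn1` gives 8380 nM. Compound 2 `Cc1cc(=O)n(-c2ccc(Br)cc2F)nc1C(=O)Nc1ccc(Oc2ncnc3ccsc23)c(F)c1` gives 1550 nM. Of these two numbers, compound 2 stands lowest, and the gap to compound 1 lies beyond the usual scatter of this assay; the two compounds differ in more than one place, so no single change can be credited with that gap.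

Compound 3 `Cc1ccc(-n2nc(C(=O)Nc3ccc(Oc4ncnc5ccsc45)c(F)c3)c(C)cc2=O)cc1` has not yet been measured. Next to compound 2 it carries one change: 4-methylphenyl in place of 4-bromo-2-fluorophenyl on an aromatic nitrogen. Among the compounds with values here, no measured pair shows this exact change on its own, so its size is unknown. Compound 1 carries the same 4-methylphenyl group and gives a higher number, but on a different ether, so it is only a loose pointer. A small loss, perhaps not beyond the scatter, is expected from compound 2 to compound 3 a 1.6-fold higher number from compound 2 to compound 3 (0.21 log units; within the scatter). Compound 3 is estimated at 2500 nM, within a range of 800 nM to 8000 nM.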

Compound 3, half-maximal inhibitory concentration: 7250 nM
The estimate for compound 3 lay 2.9-fold (0.46 log units) below the measured number, and the stated range covers the measured number.
By their numbers in this assay, from the lowest: compound 2; then compounds 3 and 1 (each within the scatter of the next).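

In this assay, the aryl group on the pyridazinone nitrogen turns out to matter: with everything else held fixed, 4-methylphenyl in place of 4-bromo-2-fluorophenyl gives a 4.7-fold higher number from compound 2 to compound 3 (0.67 log units; beyond the scatter). Within the data shown here, this is the first clean reading of this position, since the earlier gap came from a pair differing in more than one place. Among these compounds, with 4-methylphenyl held fixed, exchanging the group on the ether oxygen gives a 1.2-fold lower number from compound 1 to compound 3 (0.06 log units; within the scatter), so that exchange shows no difference that can be told from the scatter, and the step at the nitrogen is the only single change here that lies beyond it.

From the compounds shown here alone, the three compounds do not show whether the bromine, the fluorine or the methyl group accounts for the step at the nitrogen, and how a plain 4-bromophenyl group, a 2-fluorophenyl group or an aminophenyl group would read at this position stays open, as does whether the step would be the same size with the ether group of compound 1. Nothing measured here explains the size of that step.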